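This account rests on a few compounds, and the source may have more. Where it says the series, first, only, none or still open, it means among the compounds named here.

In a functional assay on MDA-MB-231 cells (Homo sapiens) for inhibition, read by sulforhodamine B assay, with a stated time of 72 h (on this read-out higher numbers stand for weaker inhibition of growth and lower numbers for stronger inhibition of growth), compound 1 `CCOC(=O)/C=C/c1ccncc1-c1ccc2ccccc2c1` gives 8090 nM as its concentration for half-maximal growth inhibition. Compound 2 `COC1CN(C(=O)/C=C/c2ccncc2-c2ccc3ccccc3c2)C1` gives > 10000 nM in this assay and this is a limit of the assay, not a number. Compound 3 `COC(=O)/C=C/c1ccncc1-c1ccc2ccccc2c1` has not yet been measured. The change from compound 2 is methoxy in place of 3-methoxyazetidin-1-yl on a carbonyl carbon and so reads methoxy in place of 3-methoxyazetidin-1-yl on a carbonyl carbon. Among the measured compounds shown here, the one measured step that bears on it is an at least 1.2-fold higher number from compound 1 to compound 2 (0.09 log units; that floor lies within the scatter) and it came with 3-methoxyazetidin-1-yl in place of ethoxy on that same carbonyl carbon. Compound 3 gives that group up again, so it is expected to read close to compound 1 at 8090 nM in this assay and the step should be small, toward a lower number, perhaps none beyond the scatter. The estimated step is an at least 1.2-fold lower number from compound 2 to compound 3 (0.09 log units; that floor lies within the scatter) in size. Compound 3 is expected at 8000 nM with an estimated range from 3500 nM to 16000 nM around it.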

Compound 3, concentration for 50% growth inhibition: 4710 nM
Compound 3: the middle estimate sits 1.7-fold (0.23 log units) above what was measured, and the stated range covers the measured number.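

In this assay, among the compounds shown here, replacing 3-methoxyazetidin-1-yl with methoxy on the carbonyl carbon gives an at least 2.1-fold lower number from compound 2 to compound 3 (0.32 log units; beyond the scatter), the first step at this position to clear the scatter. That step is only a floor, since compound 2 carries a limit and not a number: the limit of > 10000 nM in this assay, at which 1 of the 3 values shown sits. Hydrogen in place of methyl on the saturated chain carbon gives a 1.7-fold lower number from compound 1 to compound 3 (0.23 log units; within the scatter), so the ethoxy and methoxy forms cannot be told apart here, and the ester of either length reads in the same range of single-digit micromolar-level values only as far as these two compounds go.

The compounds shown leave open how a carboxylic acid or a longer chain such as butoxy would read on this carbonyl carbon. They also leave open whether a plain azetidin-1-yl or a dimethylamino group there would behave as 3-methoxyazetidin-1-yl does.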